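Methyl in place of hydroxy on weak inhibitors

The compounds below may be only part of what the source reports. "The series", "measured", "known", "first", "only" and "open" are said of these compounds alone.

Measured in a functional assay on SW-620 cells (Homo sapiens) for inhibition, read by MTT assay, with a stated time of 72 h; a lower number here means a stronger inhibitor, a higher number a weaker inhibitor:
- compound 1, `O=c1cc(Cn2cc(CCc3ccccc3)nn2)c2ccc(O)cc2o1`, gives 84400 nM
- compound 2, `O=c1cc(Cn2cc(CNS(=O)(=O)c3ccc(Cl)cc3)nn2)c2ccc(O)cc2o1`, gives > 100000 nM, which is a limit of the assay and not a number
- compound 3, `Cc1ccc2nc(-c3ccc(NCc4cn(Cc5cc(=O)oc6cc(O)ccc56)nn4)cc3)sc2c1`, gives 90000 nM

In this assay compound 3 and compound 1 lie within the scatter of each other, so neither can be called the weaker of the two. For compound 2 only the limit is known. Compound 4, `Cc1ccc2c(Cn3cc(CNc4ccc(-c5nc6ccc(C)cc6s5)cc4)nn3)cc(=O)oc2c1`, differs from compound 3 by methyl in place of hydroxy on an aromatic carbon. Among the measured compounds shown here, no measured pair shows this change, so the data do not size it. The step is expected to be small, a 1.1-fold higher number from compound 3 to compound 4 (0.05 log units; within the scatter), none beyond the scatter. Compound 4 is estimated at 100000 nM, in a range from 40000 nM to 250000 nM.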

Compound 4, half-maximal inhibitory concentration: >= 100000 nM
Compound 4: only a limit was reported; the forecaster's own chance of this, stated with the estimate: 45%; the middle value lies on the limit itself.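

In this assay compound 4 gives >= 100000 nM, which is a limit of the assay and not a number. Methyl in place of hydroxy on this aromatic carbon gives an at least 1.1-fold higher number from compound 3 to compound 4 (0.04 log units; that floor lies within the scatter), the first reading of this change, and it shows no gain in strength. The step can be read only as a floor because the value of compound 4 sits at a limit: the limit of >= 100000 nM in this assay, at which 1 of the 4 values shown sits.

Going by these compounds, how far compound 4 lies past that limit stays open, and with it the true size of the step. Also open, on these data alone, is whether an amine or a methoxy group at this position would give a measurable number.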